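Chloro in place of methyl, applied a second time

The source may report more compounds than this note shows. Statements on the series, on what has been measured and on what is new or still open speak of the compounds shown alone.

Three compounds have been measured in a functional assay on Hep cells (Homo sapiens) for cytotoxicity, read by sulforhodamine B assay, with a stated time of 48 h; a lower number here means a stronger inhibitor, a higher number a weaker inhibitor:
compound 1 `O=C(c1cccnc1)c1cc(Cl)ccc1O` gives 27000 nM;
compound 2 `C=CCOc1ccc(C)cc1C(=O)c1cccnc1` gives 72000 nM;
compound 3 `Cc1ccc(O)c(C(=O)c2cccnc2)c1` gives 11000 nM.

Compound 3 has the lowest number of the three. The change from compound 3 to compound 1, (chloro in place of methyl on an aromatic carbon), moved the number by a 2.5-fold higher number from compound 3 to compound 1 (0.39 log units; beyond the scatter). Compound 2 differs from compound 3 in its core by allyl in place of hydrogen on an oxygen on an aromatic ring; read from compound 2 to compound 3 the step is a 6.5-fold lower number from compound 2 to compound 3 (0.82 log units; beyond the scatter), which leaves compound 2 with the highest number of the three.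

Compound 4 `C=CCOc1ccc(Cl)cc1C(=O)c1cccnc1` has not yet been measured in this assay. It stands to compound 2 as compound 1 stands to compound 3: chloro in place of methyl on an aromatic carbon. The surroundings are not identical, since in compound 3 the place is para to a hydroxy group while in compound 2 it is para to an allyloxy group, so this is the same kind of change rather than the same change. Resting on compound 2 at 72000 nM and on the single precedent a 2.5-fold higher number from compound 3 to compound 1 (0.39 log units; beyond the scatter), compound 4 is expected to show a step of about a 2.5-fold higher number from compound 2 to compound 4 (0.40 log units; beyond the scatter) in this assay. The estimate for compound 4 is 180000 nM, between 60000 nM and 400000 nM.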

Compound 4, half-maximal inhibitory concentration: > 100000 nM
Compound 4: a limit, no number (the forecaster's own chance of this, stated with the estimate: 25%); the middle value is on the limit's open side.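

In this assay compound 4 gives > 100000 nM, which is a limit of the assay and not a number. Chloro in place of methyl on an aromatic carbon comes out on this core as an at least 1.3-fold higher number from compound 2 to compound 4 (0.14 log units; that floor lies within the scatter), so the limit neither confirms the rise seen on the other core nor rules it out, and it fixes no size for the step: the same change on two cores in this assay, a 2.5-fold higher number (0.39 log units; beyond the scatter) from compound 3 to compound 1 and an at least 1.3-fold higher number (0.14 log units; that floor lies within the scatter) from compound 2 to compound 4; the limit leaves it open whether they differ Allyl in place of hydrogen on an oxygen on an aromatic ring comes out as an at least 3.7-fold higher number from compound 1 to compound 4 (0.56 log units; beyond the scatter), so this change keeps its direction on the chloro core as on the methyl core, beyond the scatter, while its size there stays unsettled: the same change on two cores in this assay, a 6.5-fold lower number (0.82 log units; beyond the scatter) from compound 2 to compound 3 and an at least 3.7-fold lower number (0.56 log units; beyond the scatter) from compound 4 to compound 1; the limit leaves it open whether they differ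

The compounds shown leave open how a methyl or a longer chain on that oxygen would read in this assay, since allyl is the only group there besides hydrogen. They also leave open whether a bromo or a methoxy group in the place held by chloro and methyl would follow the same course.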